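The compounds below may be only part of what the source reports. "The series", "measured", "known", "first", "only" and "open" are said of these compounds alone.

Compound 1, `CC(C)N1CCN(Cc2csc(N)c2C(=O)c2ccc(Cl)cc2)CC1`, is the starting point of this short series. In an assay on CHO cells for displacement of a labelled ligand from adenosine receptor A1 (Homo sapiens), read by scintillation counting, with a stated time of 120 min, tested at 10 uM (a higher number here means more inhibition at the concentration tested (going by the name of the read-out), a lower number less inhibition), compound 1 gives 0%. Compound 2, `Nc1scc(CN2CCN(c3cccc(F)c3F)CC2)c1C(=O)c1ccc(Cl)cc1`, carries a 2,3-difluorophenyl in place of the isopropyl on an amine nitrogen in a ring, and in this assay compound 2 gives 0%. The step of no change at the digits printed from compound 1 to compound 2 (within the scatter) lies within the scatter, so compound 2 stands level with compound 1 at the digits shown; neither measured compound shows inhibition beyond the scatter. The next compound, compound 3, `Nc1scc(CN2CCN(c3cc(F)ccc3F)CC2)c1C(=O)c1ccc(Cl)cc1`, has the same atoms as compound 2 joined differently: 2,5-difluorophenyl in place of 2,3-difluorophenyl on an amine nitrogen in a ring. Only one measured step bears on this change, the one from compound 1 to compound 2, and it moved nothing at the digits shown. With both measured compounds showing no inhibition, nothing in the data points to a shift when a 2,5-difluorophenyl takes the place of a 2,3-difluorophenyl on an amine nitrogen in a ring, so compound 3 is expected to stay where compound 2 stands, a step of no change at the digits printed from compound 2 to compound 3 (within the scatter). Compound 3 is therefore estimated at 0% in this assay, with a range from -10% to 12%.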

Compound 3, a percentage reported as inhibition, at one concentration (the size of the read-out at that concentration, not a potency): 1%
Compound 3: the middle estimate sits 1 percentage points below what was measured; the measured number falls inside the stated range.
By their numbers in this assay, from the lowest: compounds 1, 2 and 3 (each within the scatter of the next).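

In this assay the step from one difluorophenyl to its isomer is a number 1 percentage points higher from compound 2 to compound 3 (within the scatter) and so adds something that compound 2 alone could not show: at this place, on an amine nitrogen in a ring, exchanging 2,3-difluorophenyl for 2,5-difluorophenyl leaves the reading within the scatter. Measured against the isopropyl group, the step is a number 1 percentage points higher from compound 1 to compound 3 (within the scatter) and also lies within the scatter, so neither difluorophenyl group separates itself from isopropyl in this assay. No supporting evidence is available to explain why these three compounds read alike.

All three readings lie within the scatter of one another, so the compounds shown do not reveal whether any group on this ring nitrogen can produce clear inhibition, and a pyridine, a benzyl group or a chain ending in a carboxylic acid remains an open test of that question. They also leave open whether changes elsewhere on the shared core, such as replacing the amine or the chlorine on the benzoyl part with a methoxy group, would move the reading beyond the scatter.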